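The source may hold more compounds than are shown below. What is called first, only, known or untested is meant among the compounds shown, and "the series" means these compounds.

Measured so far:
compound 1 `O=C(Nc1ccccc1Cl)C(Cl)Cl` — 50200 nM
compound 2 `Cc1cccc(NC(=O)C(Cl)Cl)c1` — 41100 nM

Both compounds share the dichloroacetamide on a substituted aniline and both sit at the weak end of a functional assay on A549 cells (Homo sapiens) for antiproliferative activity, read by MTT assay, with a stated time of 72 h; on this read-out lower numbers stand for stronger inhibition and higher numbers for weaker inhibition. Compound 2 has the lower of the two numbers, but the gap to compound 1 lies within the scatter, so no order between them is drawn from these data.

Compound 3 `O=C(Nc1cccc(OC(F)(F)F)c1)C(Cl)Cl` is the next compound to be measured in this assay. It differs from compound 2 by trifluoromethoxy in place of methyl on an aromatic carbon. Going by the values given here, no step between two measured compounds is available to size this change; the only guidance is that both measured compounds lie close together at weak activity. The step from compound 2 to compound 3 is therefore expected to be small, toward a somewhat lower number, and estimated as a 1.4-fold lower number from compound 2 to compound 3 (0.14 log units; within the scatter). For compound 3 the expected value in this assay is 30000 nM, within a range of 10000 nM to 90000 nM.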

Compound 3, half-maximal inhibitory concentration: 15100 nM
The estimate for compound 3 lay 2.0-fold (0.30 log units) above the measured number; the measured number falls inside the stated range.
By their numbers in this assay, from the lowest: compound 3; then compounds 2 and 1 (each within the scatter of the next).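

In this assay, going by these compounds alone, trifluoromethoxy in place of methyl on an aromatic carbon, meta to a group of 6 heavy atoms, gives a 2.7-fold lower number from compound 2 to compound 3 (0.43 log units; beyond the scatter) as the first step that can be sized. This position therefore responds to a change of substituent, although the step is modest and rests on one pair of compounds. No accompanying measurement speaks to the origin of this step.

As far as these compounds go, it remains open whether other groups on this carbon, such as an amine, a carboxylic acid or a longer alkyl chain, would move the number in the same direction. Also open, from the compounds shown here alone, is how trifluoromethoxy would behave on another carbon of the ring, or with the dichloroacetamide replaced by another acyl group.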